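This account rests on a few compounds, and the source may have more. Where it says the series, first, only, none or still open, it means among the compounds named here.

Compound 3 `CCOC(=O)C1=Cc2ccccc2OC1(OCc1cn(-c2ccc(F)c([N+](=O)[O-])c2)nn1)C(F)(F)F` is the only one of the three measured compounds to give a number in a functional assay on MCF7 cells (Homo sapiens) for inhibition, read by MTT assay, with a stated time of 24 h; a higher number here means a weaker inhibitor, a lower number a stronger inhibitor: compound 3 gives 16200 nM. Compound 1 `CCOC(=O)C1=Cc2ccccc2OC1(OCc1cn(-c2cccc(OC)c2)nn1)C(F)(F)F` reaches only the limit > 150000 nM in this assay. Compound 2 `CCOC(=O)C1=Cc2ccccc2OC1(OCc1cn(CC(=O)Nc2ccc(C)cc2)nn1)C(F)(F)F` likewise reaches only the limit > 150000 nM. Compound 4 `CCOC(=O)C1=Cc2ccccc2OC1(OCc1cn(CC(=O)Nc2cccc(F)c2)nn1)C(F)(F)F` has not been measured; it differs from compound 3 by ((3-fluorophenyl)carbamoyl)methyl in place of 4-fluoro-3-nitrophenyl on an aromatic nitrogen. The most relevant measured step runs the other way: an at least 9.2-fold lower number from compound 2 to compound 3 (0.96 log units; beyond the scatter), where compound 2 carries a ((4-methylphenyl)carbamoyl)methyl group that is close to the group entering in compound 4. The step expected here, a 9.3-fold higher number from compound 3 to compound 4 (0.97 log units; beyond the scatter), is therefore an upward one of at least similar size, though the limit of > 150000 nM in this assay, at which 2 of the 3 values shown sit, leaves its exact size uncertain. Compound 4 is estimated at 150000 nM, within 30000 nM to 600000 nM.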

Compound 4, half-maximal inhibitory concentration: > 150000 nM
Compound 4 ended at the assay's limit; the forecaster's own chance of this, stated with the estimate: 65%; the middle value lies on the limit itself.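

On the aromatic nitrogen of the five-membered ring, putting ((3-fluorophenyl)carbamoyl)methyl in place of 4-fluoro-3-nitrophenyl gives an at least 9.2-fold higher number from compound 3 to compound 4 (0.96 log units; beyond the scatter). With 3-fluorophenyl instead of 4-methylphenyl on the amide-type nitrogen, this chain again ends at a limit and not at a number. The steps among compound 1, compound 2 and compound 4 cannot be read, since all three values are limits: the limit of > 150000 nM in this assay, at which 3 of the 4 values shown sit.

Going by these compounds, whether a plain phenyl or a nitrophenyl group on the aromatic nitrogen would give a readable number stays open. So does the outcome for an aminophenyl group there.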